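From chloro to methoxy on a shared core

The compounds below may be only part of what the source reports. "The series", "measured", "known", "first", "only" and "open" are said of these compounds alone.

In a functional assay on Molt4/C8 cells (Homo sapiens) for inhibition (on this read-out lower numbers stand for stronger inhibition and higher numbers for weaker inhibition), compound 3 `O=C1/C(=C/c2ccccc2Cl)CCCc2ccccc21` gives 37100 nM, and compound 2 `O=C1/C(=C/c2ccccc2Br)CCCc2ccccc21` gives 38400 nM. These two cannot be told apart, as the step is a 1.0-fold lower number from compound 2 to compound 3 (0.01 log units; within the scatter). The third measured compound, compound 1 `COc1cccc(/C=C2\CCCc3ccccc3C2=O)c1OC`, which also carries methoxy, reports only a limit of > 500000 nM.

Compound 4 `COc1ccccc1/C=C1\CCCc2ccccc2C1=O` replaces the chloro of compound 3 with methoxy on an aromatic carbon: methoxy in place of chloro on an aromatic carbon. The bromo-to-chloro step shows no change but involves no methoxy, so it offers little guidance. Compound 1 sits at the limit of > 500000 nM in this assay, at which 1 of the 3 values shown sits, so some weakening is expected. The expected change is a 2.2-fold higher number from compound 3 to compound 4 (0.33 log units; beyond the scatter). For compound 4 the estimated value is 80000 nM, within an expected range of 25000 nM to 350000 nM.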

Compound 4, half-maximal inhibitory concentration: 37100 nM
Compound 4: the middle estimate sits 2.2-fold (0.33 log units) above what was measured; the measured number falls inside the stated range.
By their numbers in this assay, from the lowest: compounds 3, 4 and 2 (each within the scatter of the next). At a limit, above all of these: compound 1.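

In this assay, methoxy on an aromatic carbon ortho to a large group cannot be told apart from chloro or bromo there, with no change at the digits printed from compound 3 to compound 4 (within the scatter) and a 1.0-fold lower number from compound 2 to compound 4 (0.01 log units; within the scatter). A single methoxy at this place therefore does not bring the large loss seen with compound 1, which carries a second methoxy, and hydrogen in place of that second group gives an at least 13-fold lower number from compound 1 to compound 4 (1.12 log units; beyond the scatter). This step rests on a limit rather than a number: the limit of > 500000 nM in this assay, at which 1 of the 4 values shown sits.

From the compounds shown here alone, whether the same place also accepts an amine or a carboxylic acid remains open. So does the effect of a longer chain such as ethoxy.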